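The compounds below may be only part of what the source reports. "The series", "measured", "known", "first", "only" and "open" are said of these compounds alone.

Measured so far in a functional assay on MCF7 cells (Homo sapiens) for cytotoxicity, read by MTT assay, with a stated time of 72 h; on this read-out higher numbers stand for weaker inhibition of growth and lower numbers for stronger inhibition of growth:
compound 1 `COc1ccc(CS(=O)(=O)/C=C/c2ccc(OC)c(OC)c2OC)cc1N` gives 5950 nM
compound 2 `COc1cc(/C=C/S(=O)(=O)Cc2ccc(OC)c([N+](=O)[O-])c2)cc(OC)c1` reaches only the assay limit, > 30000 nM
compound 3 `COc1ccc(CS(=O)(=O)/C=C/c2c(OC)cccc2OC)cc1N` gives 40 nM

Compound 2 stands apart in this assay: for it the read-out is a limit and not a number, as shown by the limit of > 30000 nM in this assay, at which 1 of the 3 values shown sits. Compound 1 and compound 3, both carrying an amino group, give measurable values. Compound 4 `COc1cc(/C=C/S(=O)(=O)Cc2ccc(OC)c(N)c2)cc(OC)c1` is not yet measured. It differs from compound 2 by amino in place of nitro on an aromatic carbon. Among the compounds with values here, no measured pair in the set carries this change alone, so its size cannot be read from a step; the set only shows the nitro compound at the limit and the two amino compounds with numbers. A step toward stronger inhibition of growth, beyond the scatter, is expected. Compound 4 is estimated at 3000 nM, with a range from 300 nM to 30000 nM. This means an expected step of an at least 10-fold lower number from compound 2 to compound 4 (1.00 log units; beyond the scatter).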

Compound 4, concentration for 50% growth inhibition: 490 nM
For compound 4 the middle estimate is 6.1-fold (0.79 log units) above the measured one; the range from low to high includes it.
By their numbers in this assay, from the lowest: compound 3; then compound 4; then compound 1. At a limit, above all of these: compound 2.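

In this assay, amino in place of nitro on an aromatic carbon, ortho to a methoxy group, gives an at least 61-fold lower number from compound 2 to compound 4 (1.78 log units; beyond the scatter). Within the data shown here, the earlier compounds differed in more than one place, so this is the first direct reading of the change on a single core. The size is only a bound, since compound 2 stands at a limit and not a number: the limit of > 30000 nM in this assay, at which 1 of the 4 values shown sits.

As far as these compounds go, whether a hydroxyl, dimethylamino or acetamide group at this position would compare with amino stays open. From the compounds shown here alone, whether the change carries over to the cores of compound 1 and compound 3 also stays open.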